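Iodine on the phenyl ring: an estimate for compound 4

This account rests on a few compounds, and the source may have more. Where it says the series, first, only, none or still open, it means among the compounds named here.

Compound 1 `Cc1cc2c(cc1C)C(Cl)=C(c1nnc(Nc3ccccc3)s1)CCC2`: 5780 nM
Compound 2 `S=c1[nH]nc(C2=C(Cl)c3ccccc3CCC2)o1`: 1010 nM
Compound 3 `Cc1cc2c(cc1C)C(Cl)=C(c1nnc(-c3ccccc3)o1)CCC2`: 2760 nM

All three values come from a functional assay on MDA-MB-231 cells (Homo sapiens) for antiproliferative activity, read by sulforhodamine B assay, with a stated time of 48 h; a higher number here means a weaker inhibitor of growth, a lower number a stronger inhibitor of growth. Compound 3 stands in the middle: its number is lower than that of compound 1 and higher than that of compound 2, and both gaps lie beyond the usual scatter. Compound 4 `Cc1cc2c(cc1C)C(Cl)=C(c1nnc(-c3cccc(I)c3)o1)CCC2` differs from compound 3 in one place on the phenyl ring: iodo in place of hydrogen on an aromatic carbon. For the measured compounds named here, no measured pair here shows what such a swap does. The estimated step of a 1.4-fold lower number from compound 3 to compound 4 (0.14 log units; within the scatter) is small, towards a lower number and not beyond the scatter. For compound 4 the expected value is 2000 nM, with an estimated range of 700 nM to 6000 nM.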

Compound 4, concentration for 50% growth inhibition: 2670 nM
For compound 4 the middle estimate is 1.3-fold (0.13 log units) below the measured one, and the stated range covers the measured number.
By their numbers in this assay, from the lowest: compound 2; then compounds 4 and 3 (each within the scatter of the next); then compound 1.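

Measured in this assay, putting iodo in place of hydrogen on an aromatic carbon of the phenyl ring, meta to a large group, gives a 1.0-fold lower number from compound 3 to compound 4 (0.01 log units; within the scatter). For the compounds shown here, this position therefore carries an iodine atom with no change in growth inhibition that this read-out can detect, something the earlier compounds, which offered no single-place comparison, could not show. Nothing measured here offers an explanation for this result.

From the compounds shown here alone, what an amine, a carboxylic acid or a longer chain would do at this same position remains open. A single pair also cannot show whether iodo would behave the same way on a different core.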